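Opening a ring at one nitrogen

This account rests on a few compounds, and the source may have more. Where it says the series, first, only, none or still open, it means among the compounds named here.

compound 1 `c1cc(NC2=NCCO2)cc(OC2CCCCC2)c1`: 15900 nM
compound 2 `c1ccc(COc2ccc(NC3=NCCO3)cc2)cc1`: 11100 nM

In a functional assay on MCF7 cells (Homo sapiens) for inhibition, read by sulforhodamine B assay, with a stated time of 48 h (on this read-out lower numbers stand for stronger inhibition of growth and higher numbers for weaker inhibition of growth), compound 1 gives 15900 nM and compound 2 gives 11100 nM. These two numbers lie within the usual scatter of repeated measurements, so compound 2 stands level with compound 1 and the two cannot be ranked.

Compound 3 `O=C(CCl)NC(=O)Nc1ccc(OCc2ccccc2)cc1` has not yet been measured. It differs from compound 2 in one place: a group of 7 heavy atoms (3 carbon, 1 nitrogen, 2 oxygen, 1 chlorine; no ring) in place of a group of 5 heavy atoms (3 carbon, 1 nitrogen, 1 oxygen; one five-membered non-aromatic ring with 2 hetero atoms), on a nitrogen on an aromatic ring. A one-ring group leaves, and ((chloromethyl)carbonyl)carbamoyl, which has no ring, enters in its place.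

Both measured compounds carry the group that leaves, so neither value shows what the entering group does. Any forecast is therefore a judgement with wide margins, and a result within the scatter of compound 2 would be no surprise. A moderate move towards stronger inhibition of growth is still the expectation. In this assay the expected change is a 1.9-fold lower number from compound 2 to compound 3 (0.27 log units; within the scatter). Compound 3 is estimated at 6000 nM, with an expected range of 1500 nM to 20000 nM.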

Compound 3, concentration for 50% growth inhibition: 4600 nM
Compound 3: the middle estimate sits 1.3-fold (0.12 log units) above what was measured; low and high end bracket the measured number.
By their numbers in this assay, from the lowest: compound 3; then compounds 2 and 1 (each within the scatter of the next).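

At the nitrogen on an aromatic ring, the one-ring group of compound 2 can be exchanged for ((chloromethyl)carbonyl)carbamoyl, which has no ring, without loss of growth inhibition. In this assay, the exchange gives a 2.4-fold lower number from compound 2 to compound 3 (0.38 log units; beyond the scatter), a modest step, but the first in this small set that can be read as a real difference rather than scatter. No measurement at hand explains why the number falls.

It remains open which part of the entering group accounts for the step, and a compound with a methyl group or an amine in place of the chlorine-bearing chloromethyl end would help separate the chlorine from the rest of the chain. For the compounds shown here, it also remains open whether the same exchange on the core of compound 1 would give a step of similar size, since the single step here comes from the core shared by compound 2 and compound 3.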